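This account rests on a few compounds, and the source may have more. Where it says the series, first, only, none or still open, it means among the compounds named here.

Working notes on the series. Going by the values given here, in a functional assay on HeLa cells (Homo sapiens) for antiproliferative activity, read by sulforhodamine B assay, with a stated time of 48 h (a lower number here means a stronger inhibitor of growth, a higher number a weaker inhibitor of growth), compound 1 `O=C(NCc1cn(Cc2ccc(C(F)(F)F)cc2)nn1)c1cn(-c2ccccc2)nc1-c1ccc(F)cc1` gives 250 nM, the lowest of the three numbers measured so far. Compound 2 `COc1ccc(Cn2cc(CNC(=O)c3cn(-c4ccccc4)nc3-c3ccc(F)cc3)nn2)cc1` gives 870 nM in this assay, and compound 3 `COc1cc(Cn2cc(CNC(=O)c3cn(-c4ccccc4)nc3-c3ccc(F)cc3)nn2)cc(OC)c1` gives 360 nM. The measured steps are a 3.5-fold higher number from compound 1 to compound 2 (0.54 log units; beyond the scatter), a 1.4-fold higher number from compound 1 to compound 3 (0.16 log units; within the scatter) and a 2.4-fold lower number from compound 2 to compound 3 (0.38 log units; beyond the scatter); the first and last lie beyond the scatter, the step to compound 3 within it.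

Compound 4 `O=C(NCc1cn(Cc2ccc(C(F)(F)F)cc2)nn1)c1cn(-c2ccccc2)nc1-c1ccc(Cl)cc1` differs from compound 1 by chloro in place of fluoro on an aromatic carbon. Among the compounds with values here, none of the three measured steps alters this part of the shared core; all of them exchange the group at the other end of the molecule, so no measured step bears directly on the change to compound 4. Within the data shown here, with no direct precedent, and with the exchange being a single halogen for another, the expectation is a step of no change at the digits printed from compound 1 to compound 4 (within the scatter) in this assay, that is, no change beyond the scatter. Compound 4 is therefore estimated at 250 nM in this assay, with a range of 90 nM to 700 nM.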

Compound 4, concentration for 50% growth inhibition: 1900 nM
The estimate for compound 4 lay 7.6-fold (0.88 log units) below the measured number; the whole stated range lies below it.
By their numbers in this assay, from the lowest: compounds 1 and 3 (each within the scatter of the next); then compound 2; then compound 4.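

In this assay, going by these compounds alone, the exchange of 4-fluorophenyl for 4-chlorophenyl gives a 7.6-fold higher number from compound 1 to compound 4 (0.88 log units; beyond the scatter), which shows that this position of the shared core, untouched by the earlier steps, responds to the exchange of one halogen for another. This step exceeds the largest step seen at the other end of the molecule, a 3.5-fold higher number from compound 1 to compound 2 (0.54 log units; beyond the scatter), so in this pair a single heavy atom changed on this aromatic carbon moves the number further than the exchange of trifluoromethyl for methoxy does. No available evidence accounts for the size of this step.

As far as these compounds go, a single exchange gives no trend, so the reading for hydrogen, bromo or an amino group on this aromatic carbon remains open. Also open, from the compounds shown here alone, is whether chloro in place of fluoro gives a similar step alongside the 4-methoxyphenyl of compound 2 or the 3,5-dimethoxyphenyl of compound 3.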